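Halogen exchange on the sulfonyl aryl group

The source may hold more compounds than are shown below. What is called first, only, known or untested is meant among the compounds shown, and "the series" means these compounds.

Of the compounds shown here, two have been measured. Compound 1 `CC1CCN(CC[C@@H](C)N(C)S(=O)(=O)c2cccc3ccccc23)CC1` carries a naphthyl group on the sulfonyl sulfur; in an assay on HEK293 cells for binding affinity to 5-hydroxytryptamine receptor 7 (Homo sapiens) (a lower number here means a stronger inhibitor, a higher number a weaker inhibitor), compound 1 gives 31.6 nM. Compound 2 `CC1CCN(CC[C@@H](C)N(C)S(=O)(=O)c2ccc(Cl)c(Cl)c2)CC1` carries a 3,4-dichlorophenyl group on the same sulfur; in this assay compound 2 gives 31.6 nM. Compound 2 therefore stands level with compound 1 at the digits shown, and the two values lie within the usual scatter of each other, so no order between them can be stated.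

Compound 3 `CC1CCN(CC[C@@H](C)N(C)S(=O)(=O)c2ccc(Br)c(Br)c2)CC1` has not yet been measured. Compared with compound 2, the change is 3,4-dibromophenyl in place of 3,4-dichlorophenyl on a sulfonyl sulfur; the sulfonamide nitrogen and the rest of the shared core are unchanged. Among the measured compounds shown here, no measured pair isolates this kind of exchange, so the step has to be estimated from the standing of compound 2 alone. The expectation for the step from compound 2 to compound 3 in this assay is a 1.1-fold lower number from compound 2 to compound 3 (0.02 log units; within the scatter), that is, no move beyond the scatter. Compound 3 is accordingly estimated at 30 nM in this assay, with a range from 10 nM to 100 nM.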

Compound 3, inhibition constant: 20 nM
The estimate for compound 3 lay 1.5-fold (0.18 log units) above the measured number; the measured number falls inside the stated range.
By their numbers in this assay, from the lowest: compounds 3, 1 and 2 (each within the scatter of the next).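

In this assay, among the compounds shown here, the exchange of 3,4-dichlorophenyl for 3,4-dibromophenyl on a sulfonyl sulfur gives a 1.6-fold lower number from compound 2 to compound 3 (0.20 log units; within the scatter) and is the first step that isolates a single change at this place, with the number staying inside the scatter when one halogen pair replaces the other. With the naphthyl group of compound 1 included, three aryl groups on this sulfur now stand within the scatter of each other, so no order among them can be stated and none of the three changes shown moves the number beyond the scatter. Nothing in hand bears on why the number holds across this exchange.

The compounds shown leave open whether the number moves at all at this place with a plain phenyl, a 3,4-difluorophenyl, or a phenyl group carrying a carboxylic acid or an amine. Also open, on these data alone, is whether a longer chain in place of the methyl group on the sulfonamide nitrogen would shift the reading in this assay while the aryl group stays as it is in compound 3.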